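This account rests on a few compounds, and the source may have more. Where it says the series, first, only, none or still open, it means among the compounds named here.

Measured so far:
- compound 1 `CCCCCCCC/C=C\c1c(C)nc(C)c(/C=C\CCCCCCCC)c1C` - "not determined" (no result reported)
- compound 2 `CCCCCCCC/C=C\c1c(C)c(/C=C\CCCCCCCC)c2[n+](c1C)CCC2` - 23.5 uM
- compound 3 `CCCCCCCCCCc1c(C)c(CCCCCCCCCC)c2[n+](c1C)CCCCC2` - 11.7 uM

All entries come from an ADME assay on NIH3T3 cells (Mus musculus) for cytotoxicity, read by WST assay, with a stated time of 72 h; a lower number here means that less compound is tolerated, a higher number that more compound is tolerated. Within the data shown here, only two numbers are available in this small series. Compound 2 (23.5 uM) and compound 3 (11.7 uM) lie within the usual scatter of each other, so neither can be set apart from the other. Compound 1 adds nothing to the comparison ("not determined" (no result reported)).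

The next compound to be tested is compound 4 `CCCCCCCC/C=C\c1c(C)c(/C=C/CCCCCCCC)c(C)[n+]2c1CCC2`, and its nearest reference is compound 2. The change is the two compounds have the same atoms and bonds and differ only in configuration as drawn: 1 of 2 stereo elements differ; a double bond is drawn Z in compound 2 and E in compound 4. The two compounds have the same atoms and bonds, and a double bond is drawn Z in compound 2 and E in compound 4. Among the measured compounds shown here, no pair of measured compounds differs in one place only, so the data give no direct measure of what such a change does in this assay.

The expectation therefore rests on compound 2 (23.5 uM), with no shift beyond the scatter foreseen and no firm direction. The expected step is small (a 1.1-fold lower number from compound 2 to compound 4 (0.05 log units; within the scatter)). For compound 4 the estimated value is 21 uM, with an expected range of 10 uM to 45 uM.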

Compound 4, half-maximal toxic concentration: 4 uM
For compound 4 the middle estimate is 5.3-fold (0.72 log units) above the measured one; the whole stated range lies above it.
By their numbers in this assay, from the lowest: compound 4; then compounds 3 and 2 (each within the scatter of the next).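

In this assay, among these compounds, the one change from a double bond drawn Z to one drawn E gives a 5.9-fold lower number from compound 2 to compound 4 (0.77 log units; beyond the scatter), and this is the first step that can be tied to a single change. The earlier compounds shown here offered no such pair, so configuration at this double bond had no measured effect until now. The step can be assigned to that configuration alone, and not to any change in the chains or the core, because nothing else separates the pair: the fact that compounds 2 and 4 differ only in the configuration as drawn.

The compounds shown leave open whether a compound with both double bonds drawn E would move further in the same direction, and whether the step would persist with a longer chain or with a chain ending in a carboxylic acid or an amine. This single pair gives the size of one step in one cell line, but it does not explain why the configuration matters or show that the step would recur elsewhere in the series.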